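The source may hold more compounds than are shown below. What is called first, only, known or untested is meant among the compounds shown, and "the series" means these compounds.

In an ADME assay on cells (Peritoneal macrophage, Mus musculus) for cytotoxicity, read by CCK-8 assay, with a stated time of 24 h (on this read-out lower numbers stand for higher toxicity in this test and higher numbers for lower toxicity in this test), compound 1 (`COc1ccc(S(=O)(=O)N(CC(N)=O)c2ccc(N(CC(N)=O)S(=O)(=O)c3ccc(SCCOCCOCCN=C=S)cc3)c3ccccc23)cc1`) gives > 10000 nM as a limit and not a number. Compound 2 (`COc1ccc(S(=O)(=O)N(CC(N)=O)c2ccc(N(CC(N)=O)S(=O)(=O)c3ccc(SCCOCCOCCOCCN=C=S)cc3)c3ccccc23)cc1`) gives > 10000 nM as a limit too. Compound 3 (`COc1ccc(S(=O)(=O)N(CC(N)=O)c2ccc(N(CC(N)=O)S(=O)(=O)c3ccc([S+]([O-])CCOCCOCCN=C=S)cc3)c3ccccc23)cc1`) gives > 10000 nM as a limit too. The whole picture so far is the limit of > 10000 nM in this assay, at which 3 of the 3 values shown sit, and compound 1 stands there with no number of its own.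

Compound 4 (`COc1ccc(S(=O)(=O)N(CC(N)=O)c2ccc(N(CC(N)=O)S(=O)(=O)c3ccc(S(=O)(=O)CCCN=C=S)cc3)c3ccccc23)cc1`) differs from compound 1 on an aromatic carbon, para to a large group: a group of 9 heavy atoms (4 carbon, 1 nitrogen, 2 oxygen, 2 sulfur; no ring) in place of a group of 12 heavy atoms (7 carbon, 1 nitrogen, 2 oxygen, 2 sulfur; no ring), on an aromatic carbon is the change. Within the data shown here, the one measured step bearing on it is a step that the two limits leave unreadable from compound 1 to compound 2 and it offers no size to carry over. No step beyond the scatter is therefore expected in this assay and the estimated step that the limit leaves unreadable from compound 1 to compound 4 is expected to show no clear direction. For compound 4 the expected value is 15000 nM with an estimated range from 7000 nM to 30000 nM and a limit is the likeliest report.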

Compound 4, half-maximal cytotoxic concentration: > 10000 nM
Compound 4 ended at the assay's limit; the forecaster's own chance of this, stated with the estimate: 85%; the middle value lies beyond the limit too.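

Compound 4 gives > 10000 nM in this assay, a limit and not a number. Among these compounds, no step between compound 1 and compound 4 can be read from two limits. The compounds shown leave open at what concentration any of them would show a half-maximal cytotoxic effect.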